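Aryl swap at the pyrazole carbon: compound 3 to compound 4

This account rests on a few compounds, and the source may have more. Where it says the series, first, only, none or still open, it means among the compounds named here.

Three compounds of the series carry the same core and differ only in the aryl group on the five-membered ring. In a functional assay on BJAB cells (Homo sapiens) for antiproliferative activity, with a stated time of 4 days (on this read-out higher numbers stand for an effect only at larger amounts of compound and lower numbers for an effect already at smaller amounts), compound 1 `COc1cncc(-c2c(C)nn(-c3nc(-c4ccc(Cl)c(Cl)c4)c(SC(C)C)s3)c2C(=O)O)c1` gives 21000 nM, compound 2 `Cc1cc(Cl)cc(-c2c(C)nn(-c3nc(-c4ccc(Cl)c(Cl)c4)c(SC(C)C)s3)c2C(=O)O)c1` gives 663 nM, and compound 3 `COc1ccc(C)cc1-c1c(C)nn(-c2nc(-c3ccc(Cl)c(Cl)c3)c(SC(C)C)s2)c1C(=O)O` gives 9500 nM. Compound 3 thus stands second highest of the three numbers, nearest to compound 1 and far from compound 2.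

The next step replaces the aryl group again: 3-cyano-5-(trifluoromethyl)phenyl in place of 2-methoxy-5-methylphenyl on an aromatic carbon, giving compound 4 `Cc1nn(-c2nc(-c3ccc(Cl)c(Cl)c3)c(SC(C)C)s2)c(C(=O)O)c1-c1cc(C#N)cc(C(F)(F)F)c1`. Among the measured compounds shown here, two measured steps bear on it. The step of a 14-fold higher number from compound 2 to compound 3 (1.16 log units; beyond the scatter) shows that moving from a 3-chloro-5-methylphenyl to the 2-methoxy-5-methylphenyl raised the number sharply; the step of a 2.2-fold lower number from compound 1 to compound 3 (0.34 log units; beyond the scatter) was modest. Compound 4 returns to a phenyl whose two substituents carry the same numbers in their name as in compound 2, so in this assay a large step downward, roughly the reverse of the step from compound 2, is expected, a 9.5-fold lower number from compound 3 to compound 4 (0.98 log units; beyond the scatter). For compound 4 the estimate is 1000 nM, within 300 nM to 4000 nM.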

Compound 4, half-maximal effective concentration: 3600 nM
Compound 4: middle estimate off by 3.6-fold (0.56 log units), on the low side; the measured number falls inside the stated range.
By their numbers in this assay, from the lowest: compound 2; then compound 4; then compound 3; then compound 1.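

In this assay, the 3-cyano-5-(trifluoromethyl)phenyl brings only a 2.6-fold lower number from compound 3 to compound 4 (0.42 log units; beyond the scatter) and, set against the 3-chloro-5-methylphenyl, shows a 5.4-fold higher number from compound 2 to compound 4 (0.73 log units; beyond the scatter) at this position. A phenyl with substituents at the same numbered places therefore does not match the lowest number shown, so the choice of substituents matters here as well as their numbering, while a 5.8-fold lower number from compound 1 to compound 4 (0.77 log units; beyond the scatter) keeps all three phenyl groups lower than the 5-methoxypyridin-3-yl. Nothing available gives a measured reason for these differences.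

Still open is which of the two groups in the 3-cyano-5-(trifluoromethyl)phenyl accounts for its gap to the 3-chloro-5-methylphenyl. The compounds shown also leave open how a phenyl carrying an amine or a longer alkoxy chain would behave at this position.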